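Amide aryl variation on a shared flavonol core

The compounds below may be only part of what the source reports. "The series", "measured", "known", "first", "only" and "open" are said of these compounds alone.

Compound 1 `Cc1ccc(C(=O)Nc2cccc(-c3oc4cc(-c5ccc(F)cc5)ccc4c(=O)c3O)c2)cc1`: 2320 nM
Compound 2 `O=C(Nc1cccc(-c2oc3cc(-c4ccc(F)cc4)ccc3c(=O)c2O)c1)c1ccc(C(F)(F)F)cc1`: 42700 nM
Compound 3 `Cc1cc(C(=O)Nc2cccc(-c3oc4cc(-c5ccc(F)cc5)ccc4c(=O)c3O)c2)ccc1F`: 9540 nM

In a functional assay on HepG2 cells (Homo sapiens) for antiproliferative activity, read by CCK-8 assay, with a stated time of 72 h (a lower number here means a stronger inhibitor, a higher number a weaker inhibitor), compound 2 stands highest of the three numbers: the nearest neighbour is reached by the modest step of a 4.5-fold lower number from compound 2 to compound 3 (0.65 log units; beyond the scatter), and the lowest number lies a large step away, the reverse of an 18-fold higher number from compound 1 to compound 2 (1.26 log units; beyond the scatter). Compound 4 `Cc1cc(C)cc(C(=O)Nc2cccc(-c3oc4cc(-c5ccc(F)cc5)ccc4c(=O)c3O)c2)c1` differs from compound 2 by 3,5-dimethylphenyl in place of 4-(trifluoromethyl)phenyl on a carbonyl carbon. Both measured steps bear on this: each replaces the trifluoromethyl with a methyl-bearing ring, and in each the number falls beyond the scatter. Compound 4 keeps two methyls and no fluorine on that ring, so a downward step beyond the scatter is expected, an 8.5-fold lower number from compound 2 to compound 4 (0.93 log units; beyond the scatter). Compound 4 is accordingly estimated at 5000 nM, with a range from 1500 nM to 16000 nM.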

Compound 4, half-maximal inhibitory concentration: 13400 nM
For compound 4 the middle estimate is 2.7-fold (0.43 log units) below the measured one, and the stated range covers the measured number.
By their numbers in this assay, from the lowest: compound 1; then compounds 3 and 4 (each within the scatter of the next); then compound 2.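

In this assay, a methyl-bearing ring alone does not secure the low number of compound 1: 3,5-dimethylphenyl carries two methyls yet stays clearly weaker (a 5.8-fold higher number from compound 1 to compound 4 (0.76 log units; beyond the scatter)). Against 4-(trifluoromethyl)phenyl, it recovers only part of the gap (a 3.2-fold lower number from compound 2 to compound 4 (0.50 log units; beyond the scatter)). Two differently substituted rings also give indistinguishable results (a 1.4-fold higher number from compound 3 to compound 4 (0.15 log units; within the scatter)).
No supporting data are available to explain these steps.

From the compounds shown here alone, whether an amine, a carboxylic acid or a longer chain in place of the methyl of 4-methylphenyl would keep or lower the number of compound 1 stays open. So does the effect of any change on the shared core.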